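A Methyl-for-Methoxy Swap Carried onto a Second Core

The source may report more compounds than this note shows. Statements on the series, on what has been measured and on what is new or still open speak of the compounds shown alone.

The measured compounds and their values in a functional assay on MCF7 cells (Homo sapiens) for inhibition, read by MTT assay, with a stated time of 72 h (a lower number here means a stronger inhibitor, a higher number a weaker inhibitor), are these: compound 1, `Cc1ccc(CSc2nc3nc(C)cc(Nc4cc(-c5ccccc5)[nH]n4)n3n2)cc1`, gives 7290 nM; compound 2, `COc1ccc(CSc2nc3nc(C)cc(Nc4cc(-c5ccccc5)[nH]n4)n3n2)cc1`, gives 4020 nM; compound 3, `COc1ccc(Cn2ccc(Nc3cc(C)nc4nc(SCc5ccc(Br)cc5)nn34)n2)cc1`, gives 14600 nM.

Compounds 1 and 2 share one core and differ only by methyl in place of methoxy on an aromatic carbon. That change gave a 1.8-fold higher number from compound 2 to compound 1 (0.26 log units; within the scatter), so the two values are not told apart by this assay. Compound 3 carries a different core; how the cores of compound 2 and compound 3 differ is not broken down here. In this assay compound 3 gives a higher number than compound 2, beyond the scatter, while its value and that of compound 1 lie within the scatter of each other.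

Compound 4, `Cc1ccc(Cn2ccc(Nc3cc(C)nc4nc(SCc5ccc(Br)cc5)nn34)n2)cc1`, is compound 3 with methyl in place of methoxy on an aromatic carbon. The place of the change is the same as in the pair of compounds 2 and 1, so this is the same change on the other core. Because the earlier step was a 1.8-fold higher number from compound 2 to compound 1 (0.26 log units; within the scatter), the step from compound 3 to compound 4 is expected to be small as well, about a 1.5-fold higher number from compound 3 to compound 4 (0.18 log units; within the scatter) in this assay. Compound 4 is therefore estimated to give 22000 nM in this assay, with a range from 9000 nM to 55000 nM.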

Compound 4, half-maximal inhibitory concentration: 11300 nM
Beside the measured number, compound 4's estimate is 1.9-fold (0.29 log units) above it; the range from low to high includes it.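

In this assay, methyl in place of methoxy on the core of compound 3 gave a 1.3-fold lower number from compound 3 to compound 4 (0.11 log units; within the scatter), so the assay does not tell these two compounds apart. Set beside the same change on the core of compound 1 and compound 2, the new step does not differ from the earlier one: the same change on two cores in this assay, a 1.8-fold higher number (0.26 log units; within the scatter) from compound 2 to compound 1 and a 1.3-fold lower number (0.11 log units; within the scatter) from compound 3 to compound 4, 2.3-fold (0.37 log units) apart, within the scatter of two such steps On both cores, then, the change from 4-methoxybenzyl to 4-methylbenzyl stays within the scatter, which fits a small step carrying from one core to the other, but it does not show that the change has no effect, nor does it give the change a direction, and two pairs of compounds make no general rule.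

The compounds shown leave open how an amine or a carboxylic acid on that same aromatic carbon would read in this assay, and whether any such group would move the number beyond the scatter. They also leave open whether the small step would hold on a third core.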